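The source may report more compounds than this note shows. Statements on the series, on what has been measured and on what is new or still open speak of the compounds shown alone.

Compound 1 `CC1(C)Oc2ccc(C#N)cc2[C@@H](/N=C(\NC#N)Oc2ccccc2)[C@@H]1O` carries a phenoxy group on a carbon with a double bond to nitrogen in the shared core. In a functional assay (aorta) with Rattus norvegicus as the target (on this read-out higher numbers stand for weaker inhibition and lower numbers for stronger inhibition), compound 1 gives > 100000 nM, which is a limit of the assay rather than a number (the limit of > 100000 nM in this assay, at which 1 of the 3 values shown sits). Compound 2 `CC1(C)Oc2ccc(C#N)cc2[C@@H](NC(=O)c2ccccc2)[C@@H]1O` gives 30 nM in this assay, and compound 3 `CC1(C)Oc2ccc(C#N)cc2[C@@H](NC(=O)Nc2ccncc2)[C@@H]1O` gives 8500 nM. Among the measured compounds shown here, the one measured step, a 280-fold higher number from compound 2 to compound 3 (2.45 log units; beyond the scatter), concerns a carbonyl carbon and not the carbon changed here. Compound 4 `CC(=O)c1ccc(N/C(=N/[C@@H]2c3cc(C#N)ccc3OC(C)(C)[C@H]2O)NC#N)cc1` differs from compound 1 by (4-acetylphenyl)amino in place of phenoxy on a carbon with a double bond to nitrogen. For the measured compounds named here, no measured step covers this change directly, and the only related step moved toward weaker inhibition. Compound 4 is therefore estimated at 5000 nM, within a range of 300 nM to 100000 nM, an expected at least 20-fold lower number from compound 1 to compound 4 (1.30 log units; beyond the scatter) that may still end in a limit.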

Compound 4, half-maximal inhibitory concentration: 21000 nM
Compound 4: the middle estimate sits 4.2-fold (0.62 log units) below what was measured, and the stated range covers the measured number.
By their numbers in this assay, from the lowest: compound 2; then compound 3; then compound 4. At a limit, above all of these: compound 1.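

Among the compounds shown here, at the carbon with a double bond to nitrogen, (4-acetylphenyl)amino in place of phenoxy gives an at least 4.7-fold lower number from compound 1 to compound 4 (0.67 log units; beyond the scatter), the first sign that the group on this carbon matters, as the earlier step concerned a carbonyl carbon. Compound 1 stands at a limit of the assay, so this step has no upper size: the limit of > 100000 nM in this assay, at which 1 of the 4 values shown sits.

The change swaps the oxygen for an amine nitrogen and adds the acetyl group together, and the compounds shown do not separate the two. Going by these compounds, whether a plain phenylamino group on this carbon would give a similar number remains open.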